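The source may report more compounds than this note shows. Statements on the series, on what has been measured and on what is new or still open speak of the compounds shown alone.

Of the compounds shown here, three built on one shared core have been tested in a functional assay on HepG2 cells (Homo sapiens) for inhibition, read by MTT assay, with a stated time of 48 h; a higher number here means a weaker inhibitor, a lower number a stronger inhibitor. Compound 1 `Brc1ccccc1CSc1nnc(-c2ccncc2)n1-c1ccccc1` gives 17100 nM. Compound 2 `O=C(CSc1nnc(-c2ccncc2)n1-c1ccccc1)N/N=C/c1ccc(Br)cc1` gives 5990 nM, and compound 3 `O=C(CSc1nnc(-c2ccncc2)n1-c1ccccc1)N/N=C/c1ccccc1F` gives 15200 nM. Compound 3 therefore holds the second highest of the three numbers; its value and that of compound 1 lie within the scatter of each other, while compound 2 stands clearly apart, because the step of a 2.5-fold higher number from compound 2 to compound 3 (0.40 log units; beyond the scatter) is beyond the scatter. Compound 4 `O=C(CSc1nnc(-c2ccncc2)n1-c1ccccc1)N/N=C/C=C/c1ccccc1` has not yet been measured. It differs from compound 3 by 2-phenylethenyl in place of 2-fluorophenyl on a carbon with a double bond to nitrogen. Going by the values given here, the only measured step that touches this same position is the one from compound 2 to compound 3, a modest shift, which shows that the group on this carbon can move the number by a modest amount. Among the compounds with values here, no measured compound carries a 2-phenylethenyl group, so the direction is open, and the expected step is a 1.3-fold lower number from compound 3 to compound 4 (0.10 log units; within the scatter), small and possibly within the scatter. Compound 4 is thus expected to give about 12000 nM in this assay, within a range from 4000 nM to 36000 nM.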

Compound 4, half-maximal inhibitory concentration: 8280 nM
Beside the measured number, compound 4's estimate is 1.4-fold (0.16 log units) above it, and the stated range covers the measured number.
By their numbers in this assay, from the lowest: compounds 2, 4, 3 and 1 (each within the scatter of the next, the first and the last beyond it).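

In this assay, putting 2-phenylethenyl on the carbon with a double bond to nitrogen gives a 1.8-fold lower number from compound 3 to compound 4 (0.26 log units; within the scatter) and a 1.4-fold higher number from compound 2 to compound 4 (0.14 log units; within the scatter), so compound 4 cannot be told apart from either compound, even though compound 2 and compound 3 differ clearly from each other. The position therefore accepts a group with a double bond outside aromatic rings, and not only a halogen-bearing phenyl ring directly on this carbon, while the number stays in the range those two compounds set. Nothing measured here explains this result.

All three groups compared at this position carry a six-membered aromatic ring of carbon only. Going by these compounds, how the number responds to an amine, a carboxylic acid or a plain alkyl chain on this carbon remains open.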